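Chloro for Methyl on the Biaryl Sulfonamide

A few compounds are considered here, and "the series" means these few. Any claim that something is new, unique, unknown or untested is made for them only; others in the source may bear on it.

The series shares a piperidine sulfonamide bearing a methylpiperidine, and is followed in a functional assay on DLD-1 cells (Homo sapiens) for antiproliferative activity, read by CellTiter-Glo, with a stated time of 72 h; a higher number here means a weaker inhibitor, a lower number a stronger inhibitor. Compound 1 `Cc1noc(C)c1S(=O)(=O)N1CCC(N2CCC(C)CC2)CC1` carries a dimethylisoxazole sulfonyl group, and in this assay compound 1 reaches only the limit > 5000 nM, which is a limit and not a number, as the limit of > 5000 nM in this assay, at which 1 of the 3 values shown sits, shows. Compound 2 `Cc1ccc(-c2ccccc2S(=O)(=O)N2CCC(N3CCC(C)CC3)CC2)cc1` gives 366 nM in this assay. Compound 3 `CC1CCN(C2CCN(S(=O)(=O)c3cccc(-c4ccccc4F)c3)CC2)CC1` gives 10 nM in this assay. Among the two numbers shown, compound 2 stands highest; the nearest is compound 3 with a number that is lower by a margin beyond the scatter, and one further value is a limit. Compound 4 `CC1CCN(C2CCN(S(=O)(=O)c3ccccc3-c3ccc(Cl)cc3)CC2)CC1` differs from compound 2 by a single change: chloro in place of methyl on an aromatic carbon, (chloro in place of methyl on an aromatic carbon). Going by the values given here, no measured pair shows this exact exchange, so the size of the step is uncertain. The expectation is a small step in this assay, if any, from compound 2 to compound 4, a 1.5-fold lower number from compound 2 to compound 4 (0.17 log units; within the scatter), within the scatter. Compound 4 is therefore estimated at 250 nM in this assay, with a range from 80 nM to 900 nM.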

Compound 4, half-maximal inhibitory concentration: 202 nM
Beside the measured number, compound 4's estimate is 1.2-fold (0.09 log units) above it; measured number inside the range.
By their numbers in this assay, from the lowest: compound 3; then compounds 4 and 2 (each within the scatter of the next). At a limit, above all of these: compound 1.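

In this assay, going by these compounds alone, going from 4-methylphenyl to 4-chlorophenyl gives a 1.8-fold lower number from compound 2 to compound 4 (0.26 log units; within the scatter), the first step between two compounds that differ in one place. On this aromatic carbon, para to a large group, chloro and methyl therefore cannot be told apart by this read-out, as compound 2 and compound 4 stand within the scatter of each other. Nothing available bears on why these two groups read alike.

The compounds shown leave open how this position would respond to a group of a different kind, such as an amine, a carboxylic acid or a methoxy group. They also leave open whether the same exchange of methyl for chloro would read alike on the aryl group of compound 3.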